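This account rests on a few compounds, and the source may have more. Where it says the series, first, only, none or still open, it means among the compounds named here.

- Compound 1 (`O=C(Nc1ccc2sc(-c3cccc(F)c3)nc2c1)N1CCCCC1`) in the assay that follows: (> 50 uM)
- Compound 2 (`O=C(Nc1ccc2sc(-c3ccccc3)nc2c1)N1CCCC1`) in the assay that follows: (> 50 uM)

In an ADME assay on HepG2 cells (Homo sapiens) for inhibition, read by resazurin assay, with a stated time of 48 h (on this read-out higher numbers stand for an effect only at larger amounts of compound and lower numbers for an effect already at smaller amounts), compound 2 gives > 50 uM as a limit of the assay, not a number. Compound 1 likewise gives > 50 uM as a limit. Both compounds therefore share one ceiling (the limit of > 50 uM in this assay, at which 2 of the 2 values shown sit), so no true value is known for either.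

Compound 3 (`O=C(Nc1ccc2sc(-c3cccc(F)c3)nc2c1)N1CCCC1`) changes compound 2 from phenyl to 3-fluorophenyl, with fluoro in place of hydrogen on an aromatic carbon. Within the data shown here, no measured pair shows this change alone. Compound 1 also carries 3-fluorophenyl and reads (> 50 uM) as a limit, so little change is expected. The expected step (a number no higher from compound 2 to compound 3 (the limit leaves the size open)) is estimated to stay within the scatter. For compound 3 the estimated value is 50 uM with an expected range from 30 uM to 100 uM in this read-out, most likely again reported as a limit.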

Compound 3, concentration for 90% of the maximal effect: > 50 uM
Compound 3 ended at the assay's limit (the forecaster's own chance of this, stated with the estimate: 85%); the middle value lies on the limit itself.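

No step can be read among compound 1, compound 2 and compound 3, because all three stop at the same limit: the limit of > 50 uM in this assay, at which 3 of the 3 values shown sit.

The compounds shown leave open whether fluoro in place of hydrogen, or pyrrolidin-1-yl in place of piperidin-1-yl, makes any difference in this assay.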